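Series notes: cyclopentyl to benzyl on the chain carbon

The source may report more compounds than this note shows. Statements on the series, on what has been measured and on what is new or still open speak of the compounds shown alone.

Measured in an assay on CHO cells for antagonist activity at transient receptor potential cation channel subfamily V member 1 (Homo sapiens), read by FLIPR; on this read-out lower numbers stand for stronger inhibition and higher numbers for weaker inhibition:
compound 1 `CC1CCN(c2nc(C(F)(F)F)ccc2CNC(=O)C(c2ccc(NS(C)(=O)=O)c(F)c2)C2CCCC2)CC1` — 88.7 nM
compound 2 `CS(=O)(=O)Nc1ccc(C(C(=O)NCc2ccc(C(F)(F)F)nc2SC2CCCCC2)c2ccc(F)cc2)cc1F` — 37.6 nM
compound 3 `Cc1cccc(C(C(=O)NCc2ccc(C(F)(F)F)nc2N2CCC(C)CC2)c2ccc(NS(C)(=O)=O)c(F)c2)c1` — 0.1 nM

Compound 1 gives the highest of the three numbers in this assay. Among the measured compounds shown here, compound 2, which carries a different core and a different group on the chain carbon, shows a lower number; no single-point step to compound 1 is defined for it. For the measured compounds named here, compound 3 is the furthest from compound 1, and the two form the one single-point step in the set: an 890-fold lower number from compound 1 to compound 3 (2.95 log units; beyond the scatter).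

Compound 4 `CC1CCN(c2nc(C(F)(F)F)ccc2CNC(=O)C(Cc2ccccc2)c2ccc(NS(C)(=O)=O)c(F)c2)CC1` is the next candidate. Against compound 1 the change is benzyl in place of cyclopentyl on a saturated chain carbon bound to an aromatic carbon and a carbonyl carbon. The step from compound 1 to compound 3 is the only measured one that bears on this change, and there the aromatic ring sits directly on the chain carbon. In compound 4 the aromatic ring is carried one saturated carbon further out, so the step is expected to go in the same direction but to fall well short of that size: a 4.4-fold lower number from compound 1 to compound 4 (0.65 log units; beyond the scatter) is the expected step. The estimate for compound 4 in this assay is 20 nM, with a range of 3 nM to 150 nM.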

Compound 4, inhibition constant: 65.9 nM
Compound 4: the middle estimate sits 3.3-fold (0.52 log units) below what was measured, and the stated range covers the measured number.
By their numbers in this assay, from the lowest: compound 3; then compounds 2, 4 and 1 (each within the scatter of the next, the first and the last beyond it).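

In this assay, benzyl in place of cyclopentyl on the chain carbon gives a 1.3-fold lower number from compound 1 to compound 4 (0.13 log units; within the scatter) and so does not separate these two groups, although one brings an aromatic ring and the other a non-aromatic ring. An aromatic ring at this place is therefore not enough on its own for the very low number of compound 3: benzyl in place of 3-methylphenyl gives a 660-fold higher number from compound 3 to compound 4 (2.82 log units; beyond the scatter) and is a large step, so at this position the outcome depends strongly on which aromatic group is present. No measurement at hand gives a reason for this sharp difference.

The compounds shown leave open whether the large step belongs to the methyl group of 3-methylphenyl or to the saturated carbon that benzyl carries, and an unsubstituted phenyl group and a 3-methylbenzyl group on the chain carbon would pull these two apart. As far as these compounds go, how narrow the requirement is also stays open, since a 4-methylphenyl group, a 3-chlorophenyl group or a pyridyl ring at this place would show whether the low number survives any change to the ring.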